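Ring epimer of the short fluorinated-chain compound

The source may report more compounds than this note shows. Statements on the series, on what has been measured and on what is new or still open speak of the compounds shown alone.

Measured in a functional assay on A549 cells (Homo sapiens) for inhibition, read by sulforhodamine B assay, with a stated time of 48 h; on this read-out lower numbers stand for stronger inhibition of growth and higher numbers for weaker inhibition of growth:
- compound 1 `O=C(CCC(F)(F)C(F)(F)C(F)(F)C(F)(F)F)NCCCCCCCCCN[C@@H]1[C@H](O)[C@@H](O)[C@H](O)[C@H]2COC(=O)N21`: > 100000 nM (a limit)
- compound 2 `O=C(CCC(F)(F)C(F)(F)C(F)(F)C(F)(F)C(F)(F)C(F)(F)F)NCCCCCCCCCN[C@@H]1[C@H](O)[C@@H](O)[C@H](O)[C@H]2COC(=O)N21`: 12000 nM

Compound 1 stands at > 100000 nM, which is a limit of this assay and not a number. From the compounds shown here alone, it therefore holds the weak end of the two values, and its true position is unknown.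

Compound 3 `O=C(CCC(F)(F)C(F)(F)C(F)(F)C(F)(F)F)NCCCCCCCCCN[C@@H]1[C@H](O)[C@@H](O)[C@@H](O)[C@H]2COC(=O)N21` is related to compound 1 as follows: the two compounds have the same atoms and bonds and differ only in configuration as drawn: 1 of 5 stereo elements differ; a stereocentre at a saturated ring carbon is drawn R in compound 1 and S in compound 3.

Within the data shown here, the only measured step is an at least 8.3-fold lower number from compound 1 to compound 2 (0.92 log units; beyond the scatter), with 1,1,2,2,2-pentafluoroethyl in place of fluoro on the chain. It leaves the ring carbon untouched, so it bears on this change only as a rough guide to size. Among the measured compounds shown here, no measured step covers a change of configuration. A modest move to a lower number in this assay is expected, smaller than that chain step, and a result that stays at the limit remains quite possible.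

Compound 3 is estimated at 60000 nM, with an expected range of 15000 nM to 150000 nM. The expected step is an at least 1.6-fold lower number from compound 1 to compound 3 (0.22 log units; that floor lies within the scatter).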

Compound 3, concentration for 50% growth inhibition: 76000 nM
For compound 3 the middle estimate is 1.3-fold (0.10 log units) below the measured one; measured number inside the range.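

In this assay, among these compounds, the configuration of this ring carbon is the first change that leaves the chain untouched, and drawing it S gives a number rather than a limit, with an at least 1.3-fold lower number from compound 1 to compound 3 (0.11 log units; that floor lies within the scatter). Compound 1 stays at > 100000 nM, which is a limit of the assay and not a number. Any shift between the two can be assigned to configuration alone, because nothing else separates them: the fact that compounds 1 and 3 differ only in the configuration as drawn

From the compounds shown here alone, the true size of that shift stays open, and so does whether the same inversion would act alike on the longer fluorinated chain of compound 2. Also open, going by these compounds, is how a plain hydrocarbon chain or a carboxylic acid in place of the fluorinated chain would behave in this assay with either configuration.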